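This account rests on a few compounds, and the source may have more. Where it says the series, first, only, none or still open, it means among the compounds named here.

Compound 1 `Cc1cc(-n2cccc2)cn2c(CSCCc3ccccc3)cnc12` and compound 2 `Cc1cc(-n2ccnc2)cn2c(CSCCc3ccccc3)cnc12` share one core, while compound 3 `Cc1cc(-n2cccc2)c2ncc(CSCCc3ccccc3)n2c1` and the unmeasured compound 4 `Cc1cc(-n2ccnc2)c2ncc(CSCCc3ccccc3)n2c1` share another; the difference between the two cores is not broken down here. In an ADME assay on HEL cells (Homo sapiens) for cytotoxicity, with a stated time of 3 days (a lower number here means that less compound is tolerated, a higher number that more compound is tolerated), compound 1 gives >= 4 ug/mL, which is a limit of the assay rather than a number. In this assay compound 2 gives 100 ug/mL, and compound 3 gives 100 ug/mL, level with compound 2 at the digits shown. The change from compound 1 to compound 2 is 1H-imidazol-1-yl in place of 1H-pyrrol-1-yl on an aromatic carbon, and it made a step that the limit leaves unreadable from compound 1 to compound 2, the reason being (the limit of >= 4 ug/mL in this assay, at which 1 of the 3 values shown sits). The change awaiting measurement is 1H-imidazol-1-yl in place of 1H-pyrrol-1-yl on an aromatic carbon; it is the same kind of change, though the place differs, being ortho to a fused ring in compound 3 rather than para to a fused ring as in compound 1. Compound 4 is expected to show no change at the digits printed from compound 3 to compound 4 (within the scatter) in this assay, resting on compound 3 at 100 ug/mL and on compound 2, which already carries 1H-imidazol-1-yl, at 100 ug/mL. For compound 4 the estimate in this assay is 100 ug/mL, between 50 ug/mL and 200 ug/mL.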

Compound 4, minimum cytotoxic concentration: 20 ug/mL
Estimate against measurement, compound 4: 5.0-fold (0.70 log units) above; measured number below the stated range.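

In this assay, putting 1H-imidazol-1-yl in place of 1H-pyrrol-1-yl on the core of compound 3 gives a 5.0-fold lower number from compound 3 to compound 4 (0.70 log units; beyond the scatter), so on this core the change lowers the tolerated concentration. Compound 1 gives >= 4 ug/mL, which is a limit of the assay and not a number. The same change on the other core therefore cannot be read as a step, and the series does not show whether the change keeps its size or even its direction when carried from one core to the other, because of this limit: the limit of >= 4 ug/mL in this assay, at which 1 of the 4 values shown sits.

The compounds shown leave open whether the lower number in compound 4 belongs to 1H-imidazol-1-yl in general or to its place, ortho to a fused ring, since a single readable step cannot separate the two. They also leave open how an amine or a carboxylic acid on that same aromatic carbon would read in this assay.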